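Replacing the Aryl Group of Compound 1

The compounds below may be only part of what the source reports. "The series", "measured", "known", "first", "only" and "open" are said of these compounds alone.

Compound 1 `CCN(CC)Cc1ccc2nc(NC(=O)N/N=C/c3cn(Cc4ccc(C(C)(C)C)cc4)c4ccccc34)sc2c1` is the starting point. In a functional assay on MDA-MB-231 cells (Homo sapiens) for cytotoxicity, read by MTT assay, with a stated time of 72 h (on this read-out higher numbers stand for weaker inhibition and lower numbers for stronger inhibition), compound 1 gives 2120 nM, the lowest of the three numbers measured. Its close relatives are compound 2 `CN(C)Cc1ccc2nc(NC(=O)N/N=C/c3cn(Cc4ccc(C(C)(C)C)cc4)c4ccccc34)sc2c1`, which gives 2230 nM, and compound 3 `CC1CCN(Cc2ccc3nc(NC(=O)N/N=C/c4cn(Cc5ccc(C(C)(C)C)cc5)c5ccccc45)sc3c2)CC1`, which gives 3880 nM. The steps of a 1.1-fold higher number from compound 1 to compound 2 (0.02 log units; within the scatter) and a 1.8-fold higher number from compound 1 to compound 3 (0.26 log units; within the scatter) stay within the scatter, as does a 1.7-fold higher number from compound 2 to compound 3 (0.24 log units; within the scatter). All three steps alter only the amine on the saturated chain carbon bound to an aromatic carbon. Compound 4 `CCN(CC)Cc1ccc2nc(NC(=O)N/N=C/c3cn(Cc4ccc(Cl)c(Cl)c4)c4ccccc34)sc2c1` differs from compound 1 elsewhere: 3,4-dichlorophenyl in place of 4-(tert-butyl)phenyl on a saturated chain carbon bound to an aromatic nitrogen. Among the measured compounds shown here, no measured step touches this position, so the data give no guide to direction or size. Compound 4 is therefore expected to show no shift beyond the scatter, a 1.2-fold higher number from compound 1 to compound 4 (0.07 log units; within the scatter), with an estimated this assay value of 2500 nM, ranging from 800 nM to 8000 nM.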

Compound 4, half-maximal inhibitory concentration: 4490 nM
Beside the measured number, compound 4's estimate is 1.8-fold (0.25 log units) below it; the range from low to high includes it.
By their numbers in this assay, from the lowest: compounds 1, 2, 3 and 4 (each within the scatter of the next, the first and the last beyond it).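

Putting 3,4-dichlorophenyl in place of 4-(tert-butyl)phenyl on a saturated chain carbon bound to an aromatic nitrogen gives, in this assay, a 2.1-fold higher number from compound 1 to compound 4 (0.33 log units; beyond the scatter) and is a modest change. Unlike the three amine steps, which stayed within the scatter, this step passes beyond it, so the number does respond to a change at this position. Nothing measured here explains the shift.

From the compounds shown here alone, it remains open whether losing the tert-butyl or gaining the two chlorines drives this step. A plain benzyl or a 4-chlorobenzyl group at this position could help separate the two.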